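A few compounds are considered here, and "the series" means these few. Any claim that something is new, unique, unknown or untested is made for them only; others in the source may bear on it.

Compound 1, `CCOC(=O)CNC(=O)N1CC1C#N`, in a functional assay on MCF7 cells (Homo sapiens) for inhibition (a higher number here means a weaker inhibitor, a lower number a stronger inhibitor), gives 11000 nM.
Compound 2, `N#CC1CN1C(=O)Nc1ccc(F)cc1`, in this assay gives 2700 nM.
Compound 3, `N#CC1CN1C(=O)Nc1cccc2ccccc12`, in this assay gives 2000 nM.

Among these three numbers compound 2 stands second highest. Compound 3 lies close to compound 2, within the usual scatter, so the two cannot be told apart. Compound 1 gives a clearly higher number than compound 2, beyond the scatter, so of those two compound 1 is the weaker inhibitor.

Compound 4, `N#CC1CN1C(=O)Nc1ccc(S(N)(=O)=O)cc1`, has not been measured yet. It keeps the whole of compound 2 apart from one change: sulfamoyl in place of fluoro on an aromatic carbon. Among the measured compounds shown here, no pair of measured compounds shows a change of this kind, so there is no measured step to lean on. The expectation is a modest move toward a higher number, possibly not beyond the scatter, and the expected step is a 1.4-fold higher number from compound 2 to compound 4 (0.15 log units; within the scatter). Compound 4 is estimated to give 3800 nM, with a range from 1300 nM to 11000 nM.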

Compound 4, half-maximal inhibitory concentration: > 15000 nM
Compound 4 ended at the assay's limit (the forecaster's own chance of this, stated with the estimate: 5%); middle value at least 3.9-fold (0.59 log units) away from the limit.
By their numbers in this assay, from the lowest: compounds 3 and 2 (each within the scatter of the next); then compound 1. At a limit, above all of these: compound 4.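

Among the compounds shown here, putting sulfamoyl in place of fluoro on this aromatic carbon gives the first single-place comparison: an at least 5.5-fold higher number from compound 2 to compound 4 (0.74 log units; beyond the scatter). So, at least for these two groups, what sits at this place on the ring matters to the read-out. In this assay compound 4 gives > 15000 nM, which is a limit of the assay and not a number. The step is therefore only a lower bound, and its true size stays unknown: the limit of > 15000 nM in this assay, at which 1 of the 4 values shown sits.

This one pair cannot separate the extra heavy atoms of sulfamoyl from its hydrogen-bond donor and acceptors, since the change brings them all in together. Also open, from the compounds shown here alone, is whether an amine, a carboxylic acid or a methyl sulfone at the same place would behave more like fluoro or more like sulfamoyl.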